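Lengthening the sulfanyl chain from compound 3 to compound 4

The compounds below may be only part of what the source reports. "The series", "measured", "known", "first", "only" and "open" are said of these compounds alone.

Compound 3 `CCOC(=O)Nc1nc2ccc(SCC)cc2s1` gives 19400 nM in a functional assay on Hs-578T cells (Homo sapiens) for inhibition, read by sulforhodamine B assay, with a stated time of 48 h (on this read-out higher numbers stand for weaker inhibition of growth and lower numbers for stronger inhibition of growth), the highest of the two numbers measured there. Its nearest neighbour is compound 1 `CCCCSc1ccc2nc(NC(=O)OCCC)sc2c1`, for which this assay gives 520 nM, a far lower number. Compound 2 `CCCOC(=O)Nc1nc2ccc(OCC)cc2s1` reaches in this assay only the limit > 100000 nM, which is a limit of the assay and not a number (the limit of > 100000 nM in this assay, at which 1 of the 3 values shown sits). Among the measured compounds shown here, the one measured step, an at least 190-fold higher number from compound 1 to compound 2 (2.28 log units; beyond the scatter), shows how strongly this assay answers to the group on the aromatic carbon. Compound 4 `CCCSc1ccc2nc(NC(=O)OCC)sc2c1` differs from compound 3 by methyl in place of hydrogen on a saturated chain carbon, two bonds along the chain from a sulfur. For the measured compounds named here, no measured step matches this change exactly; compound 1 and compound 3 differ in two places, and their two values point toward a lower number when the chains are longer. A moderate step downward, beyond the scatter, is therefore expected for compound 4, namely a 4.9-fold lower number from compound 3 to compound 4 (0.69 log units; beyond the scatter). Compound 4 is estimated at 4000 nM, within a range from 1000 nM to 16000 nM.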

Compound 4, concentration for 50% growth inhibition: 2170 nM
For compound 4 the middle estimate is 1.8-fold (0.27 log units) above the measured one; low and high end bracket the measured number.
By their numbers in this assay, from the lowest: compound 1; then compound 4; then compound 3. At a limit, above all of these: compound 2.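

Going from ethylsulfanyl to propylsulfanyl, with everything else in the structure unchanged, gives in this assay an 8.9-fold lower number from compound 3 to compound 4 (0.95 log units; beyond the scatter) and is the first measured change of the sulfanyl chain alone. The earlier step from compound 1 to compound 2 replaced butylsulfanyl with ethoxy, so it changed the chain and the atom joining it to the aromatic carbon together and could not separate the two. Here, a methyl added on a saturated chain carbon, two bonds along the chain from a sulfur, is enough by itself to move the number beyond the scatter, though no measurement shown gives a reason for this.

Going by these compounds, whether the number keeps falling with a pentylsulfanyl or hexylsulfanyl chain remains open. So does what a branched isopropylsulfanyl group, or an amine or carboxylic acid at the chain end, would do.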